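Amino substitution on the core: a second benzyl isomer

The source may report more compounds than this note shows. Statements on the series, on what has been measured and on what is new or still open speak of the compounds shown alone.

The series rests on a shared core carrying a chloro group, with a benzylic chloromethyl arm in two arrangements. Compound 1 `ClCc1ccc(Cn2cnc3c(Cl)ncnc32)cc1` gives 640 nM in a functional assay on CAKI-1 cells (Homo sapiens) for cytotoxicity, read by sulforhodamine B assay, with a stated time of 48 h; on this read-out higher numbers stand for weaker inhibition of growth and lower numbers for stronger inhibition of growth. Compound 2 `Nc1nc(Cl)c2ncn(Cc3ccc(CCl)cc3)c2n1` gives 9770 nM in this assay; it differs from compound 1 by amino in place of hydrogen on an aromatic carbon, and that change produced a 15-fold higher number from compound 1 to compound 2 (1.18 log units; beyond the scatter). Compound 3 `ClCc1ccccc1Cn1cnc2c(Cl)ncnc21` has the same atoms as compound 1 joined differently; the difference between the two cores is not broken down here. In this assay compound 3 gives 4170 nM, a higher number than compound 1 and a lower number than compound 2.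

Compound 4 `Nc1nc(Cl)c2ncn(Cc3ccccc3CCl)c2n1` has not yet been measured. Among the measured compounds shown here, it differs from compound 3 by amino in place of hydrogen on an aromatic carbon, and the place lines for this change and the one from compound 1 to compound 2 read the same word for word, so it is the same change on the same kind of position. For the measured compounds named here, only one prior instance exists, so the expected size carries real uncertainty. The expected step is a 9.6-fold higher number from compound 3 to compound 4 (0.98 log units; beyond the scatter), resting on the earlier rise seen in a 15-fold higher number from compound 1 to compound 2 (1.18 log units; beyond the scatter). Compound 4 is therefore estimated at 40000 nM, within 12000 nM to 150000 nM.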

Compound 4, concentration for total growth inhibition: 20400 nM
Estimate against measurement, compound 4: 2.0-fold (0.29 log units) above, and the stated range covers the measured number.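

Amino in place of hydrogen on an aromatic carbon again weakens growth inhibition on the second core, with a 4.9-fold higher number from compound 3 to compound 4 (0.69 log units; beyond the scatter) in this assay, so the direction of the change carries over from one core to the other but its size does not: the same change on two cores in this assay, a 15-fold higher number (1.18 log units; beyond the scatter) from compound 1 to compound 2 and a 4.9-fold higher number (0.69 log units; beyond the scatter) from compound 3 to compound 4, 3.1-fold (0.49 log units) apart, beyond the scatter of two such steps

Both available pairs agree in direction and neither goes against it, yet two pairs are too few to set a rule for the series or to give a dependable size for the step on a further core. Among the compounds shown here, the data also do not show what sets the two steps apart, as the only difference between the pairs is how the chloromethyl arm is arranged on the core.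

From the compounds shown here alone, it remains open whether another group at the same place, such as a methylamino group or a hydroxyl group, would behave as amino does. Also open, going by these compounds, is whether the rise would persist if the chloromethyl arm gave way to a plain methyl group.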